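The source may hold more compounds than are shown below. What is called first, only, known or untested is meant among the compounds shown, and "the series" means these compounds.

Measured so far:
Compound 1, `Nc1scc(CN2CCN(c3ccccc3)CC2)c1C(=O)c1ccc(Cl)cc1`: 1 nM
Compound 2, `Nc1scc(CN2CCN(c3ccc(Cl)cc3)CC2)c1C(=O)c1ccc(Cl)cc1`: 1.1 nM

Both compounds were tested in an assay on CHO cells for displacement of a labelled ligand from adenosine receptor A1 (Homo sapiens); a lower number here means tighter binding, a higher number weaker binding. Compound 1 gives 1 nM, and compound 2 gives 1.1 nM. The only difference between them is a chloro in place of hydrogen on an aromatic carbon, and this gave a 1.1-fold higher number from compound 1 to compound 2 (0.04 log units; within the scatter), so the two numbers cannot be told apart. Going by the values given here, compound 2 thus stands level with compound 1, the only other compound measured.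

Compound 3, `Cc1ccc(N2CCN(Cc3csc(N)c3C(=O)c3ccc(Cl)cc3)CC2)cc1`, is reached from compound 2 by methyl in place of chloro on an aromatic carbon. Among the compounds with values here, the one measured step bears on this position: putting the chloro there in the first place changed nothing beyond the scatter. Swapping that chloro for a methyl is therefore expected to leave this assay essentially unchanged, with the estimated step being no change at the digits printed from compound 2 to compound 3 (within the scatter). Compound 3 is expected to give about 1.1 nM, within the range 0.5 nM to 2.5 nM.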

Compound 3, dissociation constant: 1 nM
Compound 3: middle estimate off by 1.1-fold (0.04 log units), on the high side; the measured number falls inside the stated range.
By their numbers in this assay, from the lowest: compounds 1, 3 and 2 (each within the scatter of the next).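

In this assay, replacing 4-chlorophenyl with 4-methylphenyl gives a 1.1-fold lower number from compound 2 to compound 3 (0.04 log units; within the scatter), while the methyl in place of hydrogen gives no change at the digits printed from compound 1 to compound 3 (within the scatter). The earlier pair showed only that chloro and hydrogen could not be told apart at this place, para to a large group; methyl now joins them, so a carbon group and a halogen both leave the number within the scatter in these three compounds. No measured evidence here says why these three substituents give such similar numbers.

Going by these compounds, it remains open whether an amine, a carboxylic acid or a longer chain at this same place would also leave the number within the scatter. The compounds shown also leave open how a group at another place on this ring, or a change to the shared core, would affect binding.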